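This account rests on a few compounds, and the source may have more. Where it says the series, first, only, none or still open, it means among the compounds named here.

Compound 1 `COc1cc(/C=N/Nc2nc(-c3ccc(Br)cc3)cs2)cc(Br)c1OC`: 36200 nM
Compound 2 `COc1cc(/C=N/Nc2nc(-c3cccc(Br)c3)cs2)cc(Br)c1OC`: 43400 nM
Compound 3 `COc1cc(/C=N/Nc2nc(-c3ccc(C(F)(F)F)cc3)cs2)cc(Br)c1OC`: 65900 nM

All three were tested in a functional assay on Caco-2 cells (Homo sapiens) for inhibition, read by MTT assay, with a stated time of 48 h; a higher number here means a weaker inhibitor, a lower number a stronger inhibitor. Compound 3 gives the highest number of the three, but its neighbours sit close: the step of a 1.8-fold higher number from compound 1 to compound 3 (0.26 log units; within the scatter) and the step of a 1.2-fold higher number from compound 1 to compound 2 (0.08 log units; within the scatter) both stay inside the scatter, so the three values cannot be told apart with confidence.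

Compound 4 `COc1cc(/C=N/Nc2nc(-c3ccccc3)cs2)cc(Br)c1OC` is the next member of this series. It differs from compound 3 by hydrogen in place of trifluoromethyl on an aromatic carbon. For the measured compounds named here, the only measured step that touches the same spot is a 1.8-fold higher number from compound 1 to compound 3 (0.26 log units; within the scatter), where a swap of one substituent for another at that position moved the number by less than the scatter. Going by the values given here, the move to a bare hydrogen is a further change of the same kind, and nothing among the measured compounds suggests a large shift.

For this reason the estimated step is a 1.5-fold lower number from compound 3 to compound 4 (0.17 log units; within the scatter), essentially flat. Compound 4 is therefore expected to give about 45000 nM in this assay, with a likely range from 20000 nM to 100000 nM.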

Compound 4, half-maximal inhibitory concentration: 64200 nM
For compound 4 the middle estimate is 1.4-fold (0.15 log units) below the measured one; measured number inside the range.
By their numbers in this assay, from the lowest: compounds 1, 2, 4 and 3 (each within the scatter of the next).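

In this assay, hydrogen in place of trifluoromethyl gives a 1.0-fold lower number from compound 3 to compound 4 (0.01 log units; within the scatter), so the bare aromatic carbon and the trifluoromethyl-bearing one cannot be told apart. The earlier compounds shown here only exchanged one substituent for another, whereas the unsubstituted phenyl now gives the series a plain reference point, and both bromo compounds stay within the scatter of it, with a 1.5-fold higher number from compound 2 to compound 4 (0.17 log units; within the scatter) and a 1.8-fold higher number from compound 1 to compound 4 (0.25 log units; within the scatter). Across these four compounds, then, neither bromo, wherever it sits, nor trifluoromethyl can be separated from plain hydrogen in this assay.

Nothing measured here speaks to why these values sit so close. Going by these compounds, whether an amine or a carboxylic acid on this aromatic carbon would give a number beyond the scatter of these four remains open.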